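Swapping the Alkene Chain for an Azide on the Amide

The compounds below may be only part of what the source reports. "The series", "measured", "known", "first", "only" and "open" are said of these compounds alone.

Going by the values given here, of the two compounds measured so far, compound 1 `CCC/C=C/C(=O)N(Cc1ccc(OC)c(O)c1)c1cc(OC)c(OC)c(OC)c1` stands lowest, and in a functional assay on HCT-116 cells (Homo sapiens) for inhibition, read by MTT assay, with a stated time of 48 h (a lower number here means a stronger inhibitor, a higher number a weaker inhibitor), compound 1 gives 95 nM. Compound 2 `C/C=C/C(=O)N(Cc1ccc(OC)c(N)c1)c1cc(OC)c(OC)c(OC)c1` differs from it in more than one place, so the two are compared only by their numbers: in this assay compound 2 gives 300 nM, a gap beyond the usual scatter. Compound 3 `COc1ccc(CN(C(=O)CN=[N+]=[N-])c2cc(OC)c(OC)c(OC)c2)cc1O` has not yet been measured. It differs from compound 1 in a single place: azidomethyl in place of pent-1-en-1-yl on a carbonyl carbon. Among the compounds with values here, no pair of measured compounds shows what this exchange does, so the expectation rests on compound 1 alone. The replaced group sits on the carbonyl carbon, and since compound 1 gives 95 nM with the longer chain, a modest weakening is expected, a step of a 4.2-fold higher number from compound 1 to compound 3 (0.62 log units; beyond the scatter) in this assay. Compound 3 is therefore estimated at 400 nM, within a range from 100 nM to 1500 nM.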

Compound 3, half-maximal inhibitory concentration: 410 nM
Compound 3: middle estimate off by 1.0-fold (0.01 log units), on the low side; low and high end bracket the measured number.
By their numbers in this assay, from the lowest: compound 1; then compounds 2 and 3 (each within the scatter of the next).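

Going by these compounds alone, exchanging pent-1-en-1-yl for azidomethyl on a carbonyl carbon gives a 4.3-fold higher number from compound 1 to compound 3 (0.64 log units; beyond the scatter) in this assay, the only direct reading so far of a change at this position. The group on this carbonyl carbon therefore affects the number, yet the exchange does not remove activity: with azidomethyl in place, compound 3 still gives 410 nM. No measurement at hand gives a reason for this rise.

A single exchange cannot separate the effect of losing the pent-1-en-1-yl chain from that of gaining azidomethyl. Going by these compounds, how a saturated pentyl chain, a methyl group or an aminomethyl group on the same carbonyl carbon would read remains open, and any of these could help to tell the two apart.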